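Swapping an Ethynyl for a Furan Ring

This account rests on a few compounds, and the source may have more. Where it says the series, first, only, none or still open, it means among the compounds named here.

Measured so far:
- Compound 1 `C#Cc1cn([C@@H]2O[C@H](CO)[C@@H](O)[C@H]2O)c2ncnc(C)c12`: 1440 nM
- Compound 2 `C#Cc1cn([C@@H]2O[C@H](CO)[C@@H](O)[C@H]2O)c2ncnc(N(C)C)c12`: 36100 nM

Both compounds share one core and were tested in an ADME assay on MRC5 cells (Homo sapiens), read by MTT assay, with a stated time of 72 h; a lower number here means a stronger inhibitor, a higher number a weaker inhibitor. Among the compounds with values here, compound 1 has the lowest of the two numbers; the only step known is a 25-fold higher number from compound 1 to compound 2 (1.40 log units; beyond the scatter), which concerns a group at a different place on the core and therefore says nothing directly about the change examined here.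

Compound 3 `Cc1ncnc2c1c(-c1ccoc1)cn2[C@@H]1O[C@H](CO)[C@@H](O)[C@H]1O` differs from compound 1 as follows: furan-3-yl in place of ethynyl on an aromatic carbon. Within the data shown here, no measured step bears on this exchange, so no change beyond the scatter can be inferred from the data, and the expectation rests only on compound 1 itself. Compound 3 is therefore expected to land at 2000 nM, with a range of 400 nM to 10000 nM. This estimate corresponds to a 1.4-fold higher number from compound 1 to compound 3 (0.14 log units; within the scatter), and it should be read as a guess awaiting the number.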

Compound 3, half-maximal inhibitory concentration: 98300 nM
Beside the measured number, compound 3's estimate is 49-fold (1.69 log units) below it; measured number outside the range, above it.
By their numbers in this assay, from the lowest: compound 1; then compound 2; then compound 3.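

In this assay, the aromatic carbon that carries ethynyl proves sensitive to change: furan-3-yl in place of ethynyl gives a 68-fold higher number from compound 1 to compound 3 (1.83 log units; beyond the scatter), so this position, and not only the place altered in compound 2, can move the number well beyond the scatter. The exchange alters several things in one step, since furan-3-yl brings a ring, more heavy atoms and a hydrogen-bond acceptor, and this single step cannot separate them. No measurement shown here offers an explanation for the step.

Going by these compounds, it remains open whether a small group without a ring, such as a nitrile or a propynyl chain, would keep the number close to that of compound 1. On these data alone, it is also open whether a different ring, such as phenyl or thiophene, would behave like furan-3-yl.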